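Adding methyl to the piperidin-1-yl group of compound 2

This account rests on a few compounds, and the source may have more. Where it says the series, first, only, none or still open, it means among the compounds named here.

In an ADME assay (liver) for metabolic stability, with Liver microsome (Rattus norvegicus) as the target, using microsomes (on this read-out lower numbers stand for slow clearance and higher numbers for fast clearance), compound 2 (`O=C(O)c1csc(-n2nc(N3CCCCC3)c3ccccc32)n1`) gives 139 mL/min/kg and stands lowest of the two numbers, with compound 1 (`O=C(O)c1csc(-n2nc(-c3cccc(F)c3)c3ccccc32)n1`) at 385 mL/min/kg as its neighbour. Compound 3 (`CC1CCN(c2nn(-c3nc(C(=O)O)cs3)c3ccccc23)CC1`) carries 4-methylpiperidin-1-yl instead of piperidin-1-yl (methyl in place of hydrogen on a saturated ring carbon). Going by the values given here, the only measured step, a 2.8-fold lower number from compound 1 to compound 2 (0.44 log units; beyond the scatter) in size, exchanged 3-fluorophenyl for piperidin-1-yl and offers no direct measure of a methyl change. An estimated 1.3-fold higher number from compound 2 to compound 3 (0.10 log units; within the scatter) is therefore expected to be small and upward, probably within the scatter. For compound 3 the estimate is 175 mL/min/kg in this assay, with 95 mL/min/kg to 320 mL/min/kg as the expected range.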

Compound 3, clearance: 260 mL/min/kg
Compound 3: the middle estimate sits 1.5-fold (0.17 log units) below what was measured; measured number inside the range.
By their numbers in this assay, from the lowest: compounds 2, 3 and 1 (each within the scatter of the next, the first and the last beyond it).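

In this assay, methyl on the saturated ring carbon three ring bonds from the ring nitrogen gives a 1.9-fold higher number from compound 2 to compound 3 (0.27 log units; within the scatter), so this position tolerates this one added carbon without a change that can be told from scatter. The gain over 3-fluorophenyl is less secure than a 2.8-fold lower number from compound 1 to compound 2 (0.44 log units; beyond the scatter) suggested: with the methyl, the comparison reads a 1.5-fold lower number from compound 1 to compound 3 (0.17 log units; within the scatter), and compound 3 cannot be separated from compound 1. Nothing available explains this result.

Still open, going by these compounds, is how an ethyl, a hydroxyl or a fluorine at this ring carbon would read. Also open, on these data alone, is whether methyl on another ring carbon, or morpholine in place of the piperidine, would behave alike.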